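The compounds below may be only part of what the source reports. "The series", "measured", "known", "first", "only" and "open" are said of these compounds alone.

Measured set in a functional assay on PC-3 cells (Homo sapiens) for antiproliferative activity, read by sulforhodamine B assay, with a stated time of 48 h; on this read-out higher numbers stand for weaker inhibition and lower numbers for stronger inhibition:

Compound 1 `CC1(C)[C@@H]2CC3=NCC(=O)O[C@@]3(C)[C@H]1C2` gives 43000 nM.
Compound 2 `CC(C)(C)OC(=O)n1cnc(C[C@H]2N=C3C[C@H]4C[C@H](C4(C)C)[C@@]3(C)OC2=O)c1` gives 147000 nM.
Compound 3 `CC(C)(C)OC(=O)NCCC[C@@H]1N=C2C[C@@H]3C[C@@H](C3(C)C)[C@]2(C)OC1=O` gives 6600 nM.

Compound 3 holds the lowest number of the three, and its steps to compound 1 and to compound 2 both lie beyond the scatter, so on these numbers it is the strongest inhibitor of the set. Compound 4 `CC(C)(C)OC(=O)NCCCC[C@@H]1N=C2C[C@@H]3C[C@@H](C3(C)C)[C@]2(C)OC1=O` is not yet measured. The change from compound 3 to compound 4 is ((tert-butoxycarbonyl)amino)methyl in place of (tert-butoxycarbonyl)amino on a saturated chain carbon, three bonds along the chain from a saturated ring carbon. Within the data shown here, no pair of measured compounds shows a single step of this kind, so there is no measured step to lean on. A lengthening of the chain by one link is expected to leave the number roughly where compound 3 stands, with a 1.2-fold lower number from compound 3 to compound 4 (0.08 log units; within the scatter) estimated as a step that stays within the scatter, or at most a modest one in either direction. The estimate for compound 4 in this assay is 5500 nM, with a range from 2000 nM to 16000 nM.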

Compound 4, half-maximal inhibitory concentration: 18000 nM
For compound 4 the middle estimate is 3.3-fold (0.51 log units) below the measured one; the measured number lies above the stated range.
By their numbers in this assay, from the lowest: compound 3; then compound 4; then compound 1; then compound 2.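

In this assay, the chain length at this position is not neutral: ((tert-butoxycarbonyl)amino)methyl in place of (tert-butoxycarbonyl)amino on a saturated chain carbon gives a 2.7-fold higher number from compound 3 to compound 4 (0.44 log units; beyond the scatter) as a modest step beyond the scatter. Among these compounds, this is the first single-place step, and it runs toward weaker inhibition. Nothing measured here accounts for the step.

A single step sets no trend along the chain. Going by these compounds, how a shorter chain, or a free amine in place of the protected one, would read remains open.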